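The source may report more compounds than this note shows. Statements on the series, on what has been measured and on what is new or still open speak of the compounds shown alone.

Compound 1 `CCC(C(=O)N1CCN(c2cccc(F)c2)CC1)N1C(=O)CCC1=O` is one of two measured analogues built on a shared core. In a functional assay on the whole organism (strain Swiss) with Mus musculus as the target, in the maximal electroshock model, with a stated time of 0.25 h, at a dose of 300 mg/kg by the intraperitoneal route (a higher number here means a stronger effect of the compound at the dose given, a lower number a weaker effect), compound 1 gives 75%. Compound 2 `CCC(C(=O)N1CCN(c2cccc(C(F)(F)F)c2)CC1)N1C(=O)CCC1=O` carries a trifluoromethyl in place of fluoro on an aromatic carbon, and in this assay compound 2 gives 75%; the step of no change at the digits printed from compound 1 to compound 2 (within the scatter). On these numbers compound 1 stands level with compound 2 at the digits shown, within the scatter.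

Compound 3 `CCC(C(=O)N1CCN(c2ccc(Cl)cc2)CC1)N1C(=O)CCC1=O` has not yet been measured. It differs from compound 1 in one place: 4-chlorophenyl in place of 3-fluorophenyl on an amine nitrogen in a ring. Among the compounds with values here, only one measured step bears on this change, the exchange of one aromatic substituent for another, no change at the digits printed from compound 1 to compound 2 (within the scatter), which left the read-out unchanged. Within the data shown here, no measured pair exchanges 3-fluorophenyl for 4-chlorophenyl, so that exact change is untested. Given that the step of no change at the digits printed from compound 1 to compound 2 (within the scatter) shows no change, the expected step is no change at the digits printed from compound 1 to compound 3 (within the scatter), that is, none beyond the scatter. Compound 3 is accordingly estimated at 75%, with a range from 50% to 100%.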

Compound 3, a percentage reported as activity, at one dose (the size of the read-out at that dose, not a potency): 0%
The estimate for compound 3 lay 75 percentage points above the measured number; measured number outside the range, below it.
By their numbers in this assay, from the lowest: compound 3; then compounds 1 and 2 (each within the scatter of the next).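

In this assay, the step from 3-fluorophenyl to 4-chlorophenyl on the amine nitrogen in a ring is a number 75 percentage points lower from compound 1 to compound 3 (beyond the scatter), whereas the exchange of fluoro for trifluoromethyl gave no change at the digits printed from compound 1 to compound 2 (within the scatter), so the read-out at this part of the molecule does not hold across every change of the aromatic group. The counts do not separate the two groups: 3-fluorophenyl and 4-chlorophenyl have the same number of heavy atoms, each has one six-membered aromatic ring of carbon only, and neither has hydrogen-bond donors, hydrogen-bond acceptors or a net charge, which leaves the identity of the halogen and its numbered ring position as the differences between them. No measurement shown here accounts for the large step.

The compounds shown leave open whether the step follows the chlorine, the ring position of the halogen or the two together, a question that 3-chlorophenyl and 4-fluorophenyl at the same place would address. They also leave open how an unsubstituted phenyl would read in this assay, and whether the result for compound 3 would hold at another dose or stated time.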